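The source may hold more compounds than are shown below. What is called first, only, known or untested is meant among the compounds shown, and "the series" means these compounds.

Compound 1 `COc1ccc(-c2cc3ccccc3nc2/C=C/C(=O)c2ccccc2)cc1`: 1410 nM
Compound 2 `COc1ccc(-c2cc3ccccc3nc2/C=C/C(=O)c2ccc(F)cc2)cc1`: 820 nM
Compound 3 `COc1ccc(C(=O)/C=C/c2nc3ccccc3cc2-c2ccc(OC)cc2)cc1`: 6420 nM

These three compounds were compared in a functional assay on NCI-H1299 cells (Homo sapiens) for antiproliferative activity, read by XTT assay, with a stated time of 72 h; on this read-out lower numbers stand for stronger inhibition and higher numbers for weaker inhibition. Compound 3 stands highest of the three numbers. The two steps that lead to it, a 4.6-fold higher number from compound 1 to compound 3 (0.66 log units; beyond the scatter) and a 7.8-fold higher number from compound 2 to compound 3 (0.89 log units; beyond the scatter), are both beyond the scatter, whereas a 1.7-fold lower number from compound 1 to compound 2 (0.24 log units; within the scatter) stays within it, so compound 1 and compound 2 cannot be ordered against each other.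

Compound 4 `COc1ccc(-c2cc3ccccc3nc2/C=C/C(=O)c2c(OC)cccc2OC)cc1` has not yet been tested in this assay. It differs from compound 3 by 2,6-dimethoxyphenyl in place of 4-methoxyphenyl on a carbonyl carbon. Going by the values given here, no measured step repeats this exact change. Among the compounds with values here, the only guidance comes from the two steps that place a single methoxy on the ring attached to the carbonyl carbon, a 4.6-fold higher number from compound 1 to compound 3 (0.66 log units; beyond the scatter) and a 7.8-fold higher number from compound 2 to compound 3 (0.89 log units; beyond the scatter), where that methoxy gave a modestly higher number. Within the data shown here, a 2,6-dimethoxyphenyl has no precedent here, so the direction of its effect is open. The expectation for compound 4 is set somewhat below compound 3, close to the middle of the measured span, with wide bounds. Compound 4 is expected to give about 3500 nM, within a range from 900 nM to 14000 nM. This estimate means a step of a 1.8-fold lower number from compound 3 to compound 4 (0.26 log units; within the scatter), offered as an expectation only.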

Compound 4, half-maximal inhibitory concentration: 4710 nM
Compound 4: the middle estimate sits 1.3-fold (0.13 log units) below what was measured; measured number inside the range.
By their numbers in this assay, from the lowest: compounds 2 and 1 (each within the scatter of the next); then compounds 4 and 3 (each within the scatter of the next).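

In this assay, the step to 2,6-dimethoxyphenyl from 4-methoxyphenyl on the carbonyl carbon is a 1.4-fold lower number from compound 3 to compound 4 (0.13 log units; within the scatter), so these two methoxy-bearing rings cannot be told apart on this read-out. Each stands clearly apart from the rings without methoxy, with a 3.3-fold higher number from compound 1 to compound 4 (0.52 log units; beyond the scatter) against phenyl and a 5.7-fold higher number from compound 2 to compound 4 (0.76 log units; beyond the scatter) against 4-fluorophenyl, both beyond the scatter, so the higher number at this position is no longer tied to a single methoxy pattern but is seen with both compound 3 and compound 4. No measurement available here accounts for this shared shift.

Going by these compounds, it remains open whether a ring carrying an amine or a carboxylic acid, or a longer chain in place of methoxy, on this carbonyl carbon would fall with compound 3 and compound 4 or with compound 1 and compound 2. Equally open, on these data alone, is whether these steps would keep their size if the shared core were changed.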